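Hepatocyte Clearance Estimate for Compound 4

This account rests on a few compounds, and the source may have more. Where it says the series, first, only, none or still open, it means among the compounds named here.

In an ADME assay on cells (Hepatocyte, Rattus norvegicus) for metabolic stability (a higher number here means faster removal of the compound, a lower number slower removal), compound 1 `Cc1ccc2[nH]c(C(=O)N[C@H]3CN(S(=O)(=O)c4ccccc4)C[C@@H]3C(=O)NCCN(C)C)cc2c1` gives 16 uL/min. Compound 2 `Cc1oc(-c2ccc(Cl)cc2)nc1C(=O)N[C@H]1CN(S(=O)(=O)c2ccccc2)C[C@@H]1C(=O)N[C@H]1CCCNC1`, built on a different core, gives 1 uL/min in this assay. Compound 3 `Cc1oc(-c2ccc(C(F)(F)F)cc2)nc1C(=O)N[C@H]1CN(S(=O)(=O)c2ccccc2)C[C@@H]1C(=O)N[C@H]1CCCNC1` returns < 1 uL/min in this assay, and this is a limit of the assay rather than a number, so compound 3 stands at the limit of < 1 uL/min in this assay, at which 1 of the 3 values shown sits. The step of a number no higher from compound 2 to compound 3 (the limit leaves the size open) therefore cannot be sized: the number did not rise, and how far it fell is not readable.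

Compound 4 `Cc1oc(-c2ccccc2Cl)nc1C(=O)N[C@H]1CN(S(=O)(=O)c2ccccc2)C[C@@H]1C(=O)N[C@H]1CCCNC1` is the compound awaiting measurement. It differs from compound 3 in one place: 2-chlorophenyl in place of 4-(trifluoromethyl)phenyl on an aromatic carbon. Among the compounds with values here, the only measured step that touches this part of the molecule is a number no higher from compound 2 to compound 3 (the limit leaves the size open), where chloro stood in place of trifluoromethyl and the result was a number no higher, of unknown size. Compound 4 again carries a chlorophenyl group, as does compound 2, whose reading of 1 uL/min is a number and not a limit, and that reading is the closest guide available.

In this assay the estimated step is an at least 1.5-fold higher number from compound 3 to compound 4 (0.17 log units; that floor lies within the scatter), at most small. Compound 4 is expected to show 1.5 uL/min, between 0.5 uL/min and 5 uL/min, with a fair chance that this assay again reports only a limit.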

Compound 4, intrinsic clearance in a liver preparation (reported as CLH), per the amount of preparation that the assay uses in the Hepatocyte assay: 6.7 uL/min
Estimate against measurement, compound 4: 4.5-fold (0.65 log units) below, outside the stated range (above it).
By their numbers in the Hepatocyte assay, from the lowest: compound 2; then compound 4; then compound 1.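

Within the data shown here, in the Hepatocyte assay, the earlier compounds said nothing about where the chloro sits, and here moving from 4-chlorophenyl to 2-chlorophenyl, with the rest of the molecule unchanged, gives a 6.7-fold higher number from compound 2 to compound 4 (0.83 log units; beyond the scatter). Among these compounds, replacing 4-(trifluoromethyl)phenyl with 2-chlorophenyl gives an at least 6.7-fold higher number from compound 3 to compound 4 (0.82 log units; beyond the scatter), a floor set by a limit of the assay and not by a number, yet it shows that this position can move the read-out upward, whereas the only earlier step here showed no rise. In a physicochemical assay for lipophilicity, measured as octanol-water partition, at pH 7.4 (a lower number here means a more polar compound, a higher number a more lipophilic compound), compound 3 gives 2.3 and compound 4 gives 1.6, so within this pair the faster removal goes with the lower distribution coefficient, not the higher one.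

The compounds shown leave open whether the higher clearance belongs to the 2-chlorophenyl group alone or would also appear with a 2-fluorophenyl or 2-methoxyphenyl group in the same place. They also do not tell whether moving the chloro would give a step of similar size on the core of compound 1.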